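Amide cap variation: furan-2-yl to cyclohexyl

The compounds below may be only part of what the source reports. "The series", "measured", "known", "first", "only" and "open" are said of these compounds alone.

Compound 2 `O=C(Nc1ccc(Cl)cc1CN1C(=O)c2ccccc2C1=O)c1ccco1` gives 2300 nM in an assay on CHO cells for positive allosteric modulation of metabotropic glutamate receptor 5 (Homo sapiens), read by FLIPR; on this read-out lower numbers stand for an effect already at smaller amounts and higher numbers for an effect only at larger amounts of compound. Within the two numbers measured so far it holds the higher one; the nearest is compound 1 `COc1cccc(C(=O)Nc2ccc(Cl)cc2CN2C(=O)c3ccccc3C2=O)c1`, which in this assay gives 1500 nM, and the pair sits within the scatter of one another. Going by the values given here, the only measured step on the series is a 1.5-fold higher number from compound 1 to compound 2 (0.19 log units; within the scatter), an exchange of the group on the carbonyl carbon of the amide, and it did not move the read-out beyond the scatter.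

Compound 3 `O=C(Nc1ccc(Cl)cc1CN1C(=O)c2ccccc2C1=O)C1CCCCC1` is the next member: cyclohexyl in place of furan-2-yl on a carbonyl carbon. Among the compounds with values here, the step of a 1.5-fold higher number from compound 1 to compound 2 (0.19 log units; within the scatter) bears on this change in that it also swaps the group on the same carbonyl carbon, but it exchanged one aromatic ring for another, whereas here a six-membered non-aromatic ring of carbon only replaces the five-membered aromatic ring with one hetero atom; no measured step covers that kind of exchange. Given the small size of a 1.5-fold higher number from compound 1 to compound 2 (0.19 log units; within the scatter), compound 3 is expected to show a modest step of a 1.3-fold higher number from compound 2 to compound 3 (0.12 log units; within the scatter), with a wide uncertainty. The estimate for compound 3 is 3000 nM, within a range of 1000 nM to 10000 nM.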

Compound 3, half-maximal effective concentration: 1500 nM
Compound 3: the middle estimate sits 2.0-fold (0.30 log units) above what was measured; the range from low to high includes it.
By their numbers in this assay, from the lowest: compounds 1, 3 and 2 (each within the scatter of the next).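

Cyclohexyl in place of furan-2-yl on the carbonyl carbon gives a 1.5-fold lower number from compound 2 to compound 3 (0.19 log units; within the scatter) in this assay, and cyclohexyl in place of 3-methoxyphenyl gives no change at the digits printed from compound 1 to compound 3 (within the scatter). Going by these compounds alone, this is the first exchange at this position that leaves the aromatic rings behind, and the read-out stays within the scatter: among compounds 1, 2 and 3, an aromatic ring on the carbonyl carbon is not needed for a number in this range, nor is the hydrogen-bond acceptor counted in furan-2-yl, since cyclohexyl has none. Nothing at hand speaks to why these three groups read alike.

Open, on these data alone, is whether this tolerance extends beyond ring groups of this size, for instance to a longer open chain such as n-hexyl, or to a cyclohexyl ring carrying an amine or a carboxylic acid. Also open, as far as these compounds go, is whether the same flat picture would hold with the rest of the shared core altered, since all three compounds differ only in the group on the carbonyl carbon.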